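Series notes: the step from compound 2 to compound 4

The source may report more compounds than this note shows. Statements on the series, on what has been measured and on what is new or still open speak of the compounds shown alone.

Of the compounds shown here, three have values so far in a functional assay on Caco-2 cells (Homo sapiens) for inhibition, read by MTT assay, with a stated time of 48 h; on this read-out higher numbers stand for weaker inhibition and lower numbers for stronger inhibition. Compound 1 (`Fc1ccc(/C=N/Nc2nc(-c3ccc(C(F)(F)F)cc3)cs2)cc1F`) gives 14600 nM, compound 2 (`COc1ccccc1-c1csc(N/N=C/c2ccc(F)c(F)c2)n1`) gives 25200 nM, and compound 3 (`COc1cc(/C=N/Nc2nc(-c3ccc(F)c(F)c3)cs2)cc(Br)c1OC`) gives 21200 nM. Compound 2 stands level with the other two: its number lies within the scatter of compound 3, the nearest, and also within the scatter of compound 1, the furthest. Among the compounds with values here, the set therefore shows no separation, and no measured pair yet isolates a single structural change.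

Compound 4 (`Fc1ccc(/C=N/Nc2nc(-c3ccc(Br)cc3)cs2)cc1F`) has not been measured in this assay. It comes from compound 2 by one change: 4-bromophenyl in place of 2-methoxyphenyl on an aromatic carbon, next to the ring nitrogen (4-bromophenyl in place of 2-methoxyphenyl on an aromatic carbon). Within the data shown here, with no single-change step available, the only guide is the narrow spread of the three values, running from compound 1 at 14600 nM to compound 2 at 25200 nM. No step beyond the scatter is expected in this assay, in either direction. The expected step of a 1.4-fold lower number from compound 2 to compound 4 (0.15 log units; within the scatter) is accordingly small. For compound 4 the estimated value is 18000 nM, with an expected range of 9000 nM to 36000 nM.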

Compound 4, half-maximal inhibitory concentration: 43900 nM
Compound 4: middle estimate off by 2.4-fold (0.39 log units), on the low side; measured number outside the range, above it.
By their numbers in this assay, from the lowest: compounds 1, 3, 2 and 4 (each within the scatter of the next, the first and the last beyond it).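

In this assay, 4-bromophenyl in place of 2-methoxyphenyl on an aromatic carbon of the five-membered aromatic ring gives a 1.7-fold higher number from compound 2 to compound 4 (0.24 log units; within the scatter), so this position takes the exchange, including the loss of the hydrogen-bond acceptor counted in the leaving group, without a step that stands clear of the scatter. The series now also has its first single-change step beyond the scatter: bromo in place of trifluoromethyl on an aromatic carbon gives a 3.0-fold higher number from compound 1 to compound 4 (0.48 log units; beyond the scatter), a modest step that rests on this one pair alone. No measurement shown here accounts for either step.

As far as these compounds go, whether the separation between compound 1 and compound 4 extends to other kinds of group remains open, and a carboxylic acid or a dimethylamino group in place of the bromo would test this. Also open, from the compounds shown here alone, is whether either step holds on a different core, as both are read only on the core of compound 4.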